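The source may report more compounds than this note shows. Statements on the series, on what has been measured and on what is new or still open speak of the compounds shown alone.

Measured so far in a functional assay for inhibition, with Homo sapiens as the target; a lower number here means tighter binding, a higher number weaker binding:
Compound 1 `O=C(O)CC/C=C\CC1COC(c2cccc3ccccc23)OC1c1cccnc1`: 631 nM
Compound 2 `Cc1ccc(OC(C)(C)C2OCC(C/C=C\CCC(=O)O)C(c3cccnc3)O2)cc1`: 631 nM

Compound 2 stands level with compound 1, and the two cannot be told apart within the scatter of the measurement. The next compound, compound 3 `COc1ccc(OC(C)(C)C2OCC(C/C=C\CCC(=O)O)C(c3cccnc3)O2)c([N+](=O)[O-])c1`, has not yet been measured in this assay. It keeps the rest of compound 2 but carries 4-methoxy-2-nitrophenyl in place of 4-methylphenyl on an oxygen on a saturated carbon.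

Among the measured compounds shown here, no measured pair here differs in one place only, so the data give no direct guide to the size of this step. For the measured compounds named here, the only hint is that compound 1 at 631 nM and compound 2 at 631 nM match, although they carry different groups on the shared core. On that thin basis, a large loss is not expected, and a modest move towards tighter binding is the working expectation, with a wide margin either way. The estimated change is a 3.2-fold lower number from compound 2 to compound 3 (0.50 log units; beyond the scatter). Compound 3 is expected at 200 nM, with an estimated range of 30 nM to 800 nM.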

Compound 3, dissociation constant: 6.17 nM
For compound 3 the middle estimate is 32-fold (1.51 log units) above the measured one; the whole stated range lies above it.
By their numbers in this assay, from the lowest: compound 3; then compounds 1 and 2 (each within the scatter of the next).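

In this assay, putting 4-methoxy-2-nitrophenyl in place of 4-methylphenyl on an oxygen on a saturated carbon gives a 100-fold lower number from compound 2 to compound 3 (2.01 log units; beyond the scatter) with the rest of compound 2 unchanged. Among the compounds shown here, this is the first comparison that isolates this position, and it shows that the number responds strongly to the group carried there. The six-membered aromatic ring of carbon only stays, while the entering group adds nitrogen and oxygen atoms, a double bond outside aromatic rings and hydrogen-bond acceptors, and nothing at hand gives a measured reason for the size of the step.

As far as these compounds go, the methoxy and nitro groups enter together, so the share of each in this step remains open, and a ring carrying only one of them would be needed to separate the two. From the compounds shown here alone, it is also open how an amine or a nitrile in place of the nitro group, or a chloro group in place of the methoxy group, would read in this assay and whether any part of the step would survive.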